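Series notes: halogenated aryl on the triazole in compound 4

This account rests on a few compounds, and the source may have more. Where it says the series, first, only, none or still open, it means among the compounds named here.

In a functional assay on A549 cells (Homo sapiens) for antiproliferative activity, read by MTT assay, with a stated time of 48 h (a lower number here means a stronger inhibitor, a higher number a weaker inhibitor), compound 3 `CCOc1ccccc1-n1nncc1CN1C(=O)C2(C(C#N)=C(N)Oc3c(N)cc4nc5ccccc5nc4c32)c2ccccc21` reports only a limit, > 50000 nM. Compound 2 `CC(=O)Nc1ccc(-n2nncc2CN2C(=O)C3(C(C#N)=C(N)Oc4c(N)cc5nc6ccccc6nc5c43)c3ccccc32)cc1` likewise reports a limit, > 50000 nM. Compound 1 `N#CC1=C(N)Oc2c(N)cc3nc4ccccc4nc3c2C12C(=O)N(Cc1cnnn1-c1ccccc1Br)c1ccccc12` gives 27400 nM. The steps of an at least 1.8-fold higher number from compound 1 to compound 2 (0.26 log units; that floor lies within the scatter) and an at least 1.8-fold higher number from compound 1 to compound 3 (0.26 log units; that floor lies within the scatter) rest on that floor, (the limit of > 50000 nM in this assay, at which 2 of the 3 values shown sit), and a step that the two limits leave unreadable from compound 2 to compound 3 cannot be read. Compound 4 `N#CC1=C(N)Oc2c(N)cc3nc4ccccc4nc3c2C12C(=O)N(Cc1cnnn1-c1cc(Cl)ccc1Cl)c1ccccc12` is reached by 2,5-dichlorophenyl in place of 2-ethoxyphenyl on an aromatic nitrogen. The step of an at least 1.8-fold higher number from compound 1 to compound 3 (0.26 log units; that floor lies within the scatter) bears on it, as it swaps a halogen on the ring for ethoxy; compound 4 brings halogens back. Because compound 1 gives 27400 nM with its halogenated ring, compound 4 is expected to give 30000 nM, range 12000 nM to 80000 nM. That expectation amounts to an at least 1.6-fold lower number from compound 3 to compound 4 (0.22 log units; that floor lies within the scatter), though the limit on compound 3 leaves its true size uncertain.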

Compound 4, half-maximal inhibitory concentration: 10900 nM
Compound 4: the middle estimate sits 2.8-fold (0.44 log units) above what was measured; the whole stated range lies above it.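

In this assay, the 2,5-dichlorophenyl group separates compound 4 from both compounds held at the limit, with steps that are floors (an at least 4.5-fold lower number from compound 3 to compound 4 (0.66 log units; beyond the scatter)) and (an at least 4.5-fold lower number from compound 2 to compound 4 (0.66 log units; beyond the scatter)): the limit of > 50000 nM in this assay, at which 2 of the 4 values shown sit.
Within the data shown here, the two halogenated aryl groups also differ from each other (a 2.5-fold lower number from compound 1 to compound 4 (0.40 log units; beyond the scatter)), the first fully readable step at this position.

The step between compound 2 and compound 3 cannot be read, as both values are limits. On these data alone, whether the gain follows the second chlorine, its place or the swap from bromine stays open, as does how a 2-chlorophenyl or an aminophenyl group would read here.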